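Ring swap on the shared core: morpholine to piperidine

A few compounds are considered here, and "the series" means these few. Any claim that something is new, unique, unknown or untested is made for them only; others in the source may bear on it.

Of the compounds shown here, two have numbers so far. Compound 1 `C[C@@H]1CN(c2ccc(-c3n[nH]c4cnc(N5[C@H](C)CN(C(=O)N(C)C)C[C@@H]5C)nc34)cn2)CCN1` gives 6.4 nM in an assay on Sf9 cells for inhibition of activin receptor type-1 (Homo sapiens), read by HTRF, with a stated time of 3 h, in the presence of a further agent that is not named here; on this read-out lower numbers stand for stronger inhibition and higher numbers for weaker inhibition. Compound 2 `C[C@@H]1CN(c2ccc(-c3n[nH]c4cnc(N5[C@H](C)COC[C@@H]5C)nc34)cn2)CCN1` gives 23 nM in this assay. Compound 2 therefore stands at the higher, weaker end of the two numbers, and its gap to compound 1 lies beyond the usual scatter of repeat measurements.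

Compound 3 `CC1CCCCN1c1ncc2[nH]nc(-c3ccc(N4CCN[C@H](C)C4)nc3)c2n1` has not been measured. It differs from compound 2 in one place: 2-methylpiperidin-1-yl in place of 3,5-dimethylmorpholin-4-yl on an aromatic carbon, on an aromatic carbon of a six-membered aromatic ring with two nitrogen, between two ring nitrogen atoms, meta to a fused ring and para to a fused ring. The ring that enters carries one hetero atom where the leaving ring carried two, and one methyl where there were two.

Going by the values given here, no pair of measured compounds differing in one place is available, so the size of this step rests on the structural change alone. For compound 3 the expectation is a step of a 1.7-fold higher number from compound 2 to compound 3 (0.24 log units; within the scatter) in this assay, of modest size and more likely toward weaker inhibition than stronger, though a result within the scatter is also plausible. Compound 3 is estimated at 40 nM, with a range from 12 nM to 130 nM.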

Compound 3, half-maximal inhibitory concentration: 8.1 nM
Compound 3: middle estimate off by 4.9-fold (0.69 log units), on the high side; the measured number lies below the stated range.
By their numbers in this assay, from the lowest: compounds 1 and 3 (each within the scatter of the next); then compound 2.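

In this assay, the position on an aromatic carbon between two ring nitrogen atoms accepts a ring with one hetero atom and one methyl: 2-methylpiperidin-1-yl in place of 3,5-dimethylmorpholin-4-yl gives a 2.8-fold lower number from compound 2 to compound 3 (0.45 log units; beyond the scatter). The ring oxygen and the second methyl of the leaving group are therefore not needed for a low number here, and the simpler ring brings compound 3 to 8.1 nM, within the scatter of compound 1 at 6.4 nM, which carries a larger substituent at the same place. Nothing available accounts for the size of this step, which combines the loss of the oxygen, the loss of a methyl and the loss of two defined stereocentres in one change.

On these data alone, how much of the step belongs to each of these parts stays open, and so does any difference between the separate mirror forms of the 2-methylpiperidin-1-yl group. Also open, as far as these compounds go, is whether an unsubstituted piperidin-1-yl group, or a 2-methylpiperidin-1-yl ring bearing an amine or a carboxylic acid, would hold the number at this position.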